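Shortening the amine substituent on the shared core

The source may report more compounds than this note shows. Statements on the series, on what has been measured and on what is new or still open speak of the compounds shown alone.

Measured so far:
compound 1 `CSc1nc(-c2ccc(F)cc2)c(-c2ccnc(NC3CCc4ccccc43)c2)[nH]1` — 12%
compound 2 `CSc1nc(-c2ccc(F)cc2)c(-c2ccnc(NC(C)CCc3ccccc3)c2)[nH]1` — 5%

In an assay on isolated protein for inhibition of RAC-alpha serine/threonine-protein kinase (Homo sapiens), tested at 10 uM (a lower number here means less inhibition, a higher number more inhibition at the concentration tested (going by the name of the read-out)), compound 2 shows the lowest of the two numbers, with compound 1 nearest; the step of a number 7 percentage points lower from compound 1 to compound 2 (within the scatter) is within the scatter. Compound 3 `CCC(Nc1cc(-c2[nH]c(SC)nc2-c2ccc(F)cc2)ccn1)c1ccccc1` differs from compound 2 by 1-phenylpropyl in place of 1-methyl-3-phenylpropyl on a nitrogen on an aromatic ring. Within the data shown here, only the step between compound 1 and compound 2 touches the same nitrogen, and it was within the scatter, so no step beyond the scatter is expected in this assay, giving an expected a number 2 percentage points higher from compound 2 to compound 3 (within the scatter). Compound 3 is therefore estimated at 7%, within a range of 0% to 20%.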

Compound 3, a percentage reported as inhibition, at one concentration (the size of the read-out at that concentration, not a potency): 14%
Compound 3: middle estimate off by 7 percentage points, on the low side; the range from low to high includes it.
By their numbers in this assay, from the lowest: compounds 2, 1 and 3 (each within the scatter of the next).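

In this assay, 1-phenylpropyl on the nitrogen gives a number 9 percentage points higher from compound 2 to compound 3 (within the scatter) when it replaces 1-methyl-3-phenylpropyl, and a number 2 percentage points higher from compound 1 to compound 3 (within the scatter) when it replaces 2,3-dihydro-1H-inden-1-yl. All three substituents on this nitrogen therefore lie within the scatter of one another, so this assay does not tell them apart, whether the chain is shortened or the ring of compound 1 is opened. No available evidence bears on this result. The compounds shown leave open whether a phenyl ring carrying an amine or a carboxylic acid on this nitrogen would give a step beyond the scatter.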